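Amino in place of nitro on compound 3

The compounds below may be only part of what the source reports. "The series", "measured", "known", "first", "only" and "open" are said of these compounds alone.

In a functional assay on DU-145 cells (Homo sapiens) for cytotoxicity, read by trypan blue exclusion, with a stated time of 96 h (a higher number here means a weaker inhibitor, a lower number a stronger inhibitor), compound 1 `COc1ccc(CS(=O)(=O)/C=C/c2c(OC)cccc2OC)cc1[N+](=O)[O-]` gives 20000 nM as its reading, and compound 2 `COc1ccc(CS(=O)(=O)/C=C/c2c(OC)cccc2OC)c([N+](=O)[O-])c1` gives 50000 nM as its reading. Compound 3 `COc1cc(OC)c(/C=C/SCc2ccc(OC)c([N+](=O)[O-])c2)c(OC)c1` gives 5000 nM and holds the lowest number of the three, with its gaps to both others beyond the scatter.

The next compound, compound 4 `COc1cc(OC)c(/C=C/SCc2ccc(OC)c(N)c2)c(OC)c1`, carries amino in place of nitro on an aromatic carbon, ortho to a methoxy group (amino in place of nitro on an aromatic carbon). Among the compounds with values here, no measured pair isolates this change, so the data give no direct size for it. The expectation therefore rests on the structural change alone and is loose. The spread so far runs from compound 3 at 5000 nM to compound 2 at 50000 nM in the same read-out.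

In this assay the expected 5.0-fold lower number from compound 3 to compound 4 (0.70 log units; beyond the scatter) points toward a lower number, beyond the scatter but uncertain in size. Compound 4 is estimated at 1000 nM with an expected range of 100 nM to 10000 nM in this working estimate.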

Compound 4, half-maximal inhibitory concentration: 50 nM
Estimate against measurement, compound 4: 20-fold (1.30 log units) above; measured number outside the range, below it.
By their numbers in this assay, from the lowest: compound 4; then compound 3; then compound 1; then compound 2.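

In this assay, within the data shown here, amino in place of nitro on an aromatic carbon, ortho to a methoxy group, gives a 100-fold lower number from compound 3 to compound 4 (2.00 log units; beyond the scatter), the first step that isolates a single change. With the rest of compound 3 held fixed, the group on this one carbon is enough to produce a large step, so this position is highly sensitive to the identity of its substituent. No measurement shown for either group bears on the step, and its cause remains unassigned.

As far as these compounds go, it remains open whether amino is a particular requirement at this position, or whether a hydroxyl, an acetamide or a dimethylamino group would give a similar reading. From the compounds shown here alone, it is also open whether the same exchange would give a step of similar size on the core of compound 1.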